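The source may hold more compounds than are shown below. What is called first, only, known or untested is meant among the compounds shown, and "the series" means these compounds.

Measured compounds:
- Compound 1 `CCCCNc1nc(N)nc2ccn(Cc3ccsc3)c12`: in an ADME assay on HEK293 cells (Homo sapiens) for cytotoxicity, read by ATP content, with a stated time of 6 h (on this read-out higher numbers stand for lower toxicity in this test and lower numbers for higher toxicity in this test), compound 1 gives a limit of > 24000 nM.
- Compound 2 `COCCCNc1nc(N)nc2ccn(Cc3ccccn3)c12`: in this assay compound 2 gives a limit of > 24000 nM.
- Compound 3 `Cc1nnc(CNc2nc(N)nc3ccn(Cc4ccccn4)c23)o1`: in this assay compound 3 gives a limit of > 24000 nM.

Compound 3 stands only at a limit, as do the other two values shown (the limit of > 24000 nM in this assay, at which 3 of the 3 values shown sit). For the measured compounds named here, the one step that changes the same place, a step that the two limits leave unreadable from compound 2 to compound 3, is therefore unreadable in size and gives no measured guidance. Compound 4 `CC(C)c1cc(CNc2nc(N)nc3ccn(Cc4ccccn4)c23)no1` differs from compound 3 by 5-isopropyl-1,2-oxazol-3-yl in place of 5-methyl-1,3,4-oxadiazol-2-yl on a saturated chain carbon bound to a nitrogen on an aromatic ring. Going by the values given here, no measured step bears readably on this change, so no step beyond the scatter is expected in this assay. Compound 4 is estimated at 30000 nM, range 15000 nM to 60000 nM, most likely again reported only as a limit. The expected step is a step that the limit leaves unreadable from compound 3 to compound 4.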

Compound 4, half-maximal cytotoxic concentration: > 24000 nM
Compound 4: only a limit was reported; the forecaster's own chance of this, stated with the estimate: 80%; the middle value does not contradict the limit.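

No new step can be read for compound 4 against compound 3 or compound 2, as each value is only a limit: the limit of > 24000 nM in this assay, at which 4 of the 4 values shown sit.

The compounds shown leave open at what concentration any of them becomes cytotoxic, and whether the exchanged groups differ at all.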